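Amidine replaced by methoxyoxalylamino: expectation for compound 4

The source may hold more compounds than are shown below. What is called first, only, known or untested is meant among the compounds shown, and "the series" means these compounds.

In a functional assay on the whole organism (strain albino) for inhibition, with Rattus norvegicus as the target, read by paw edema, with stated times of 1 h and 3 h, at a dose of 20 mmol/kg by the intraperitoneal route (on this read-out higher numbers stand for a stronger effect at the one dose given and lower numbers for a weaker effect), the measured compounds give:
compound 1 `COc1ccc(N/C=N/C2=C(C#N)C3C(N4CCCC4)CCCCN3C(=O)N2c2ccccc2)cc1`: 50.2%
compound 2 `N#CC1=C(NCN2CCCCC2)N(c2ccccc2)C(=O)N2CCCCC(N3CCCC3)C12`: 42.1%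
compound 3 `N#CC1=C(/N=C/Nc2ccccc2)N(c2ccccc2)C(=O)N2CCCCC(N3CCCC3)C12`: 79.3%

Compound 3 stands highest of the three, with both steps to it beyond the scatter: a number 29.1 percentage points higher from compound 1 to compound 3 (beyond the scatter) and a number 37.2 percentage points higher from compound 2 to compound 3 (beyond the scatter). Compound 4 `COC(=O)C(=O)NC1=C(C#N)C2C(N3CCCC3)CCCCN2C(=O)N1c1ccccc1` differs from compound 3 by a group of 7 heavy atoms (3 carbon, 1 nitrogen, 3 oxygen; no ring) in place of a group of 9 heavy atoms (7 carbon, 2 nitrogen; one six-membered aromatic ring of carbon only), on a double-bonded ring carbon. The step that bears on this is a number 37.2 percentage points higher from compound 2 to compound 3 (beyond the scatter), where the group without the aromatic ring gave the lower number; a number 29.1 percentage points higher from compound 1 to compound 3 (beyond the scatter) concerns only the methoxy on the aromatic ring and bears less. Compound 4 again lacks that ring, so a downward step beyond the scatter is expected, a number 34.3 percentage points lower from compound 3 to compound 4 (beyond the scatter). Compound 4 is therefore estimated at 45%, within 28% to 65%.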

Compound 4, a percentage reported as inhibition, in the whole organism at one dose (the size of the read-out at that dose, not a potency): 88.3%
Estimate against measurement, compound 4: 43.3 percentage points below, outside the stated range (above it).
By their numbers in this assay, from the lowest: compounds 2 and 1 (each within the scatter of the next); then compounds 3 and 4 (each within the scatter of the next).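

In this assay, an aromatic ring in the group on the double-bonded ring carbon is not required for a high number: ((methoxycarbonyl)carbonyl)amino has no ring, yet compound 4 matches compound 3 within the scatter (a number 9 percentage points higher from compound 3 to compound 4 (within the scatter)). Lacking the aromatic ring therefore does not by itself give the low number seen for compound 2 (a number 46.2 percentage points higher from compound 2 to compound 4 (beyond the scatter)), and the methoxy-bearing group of compound 1 also falls short of this group (a number 38.1 percentage points higher from compound 1 to compound 4 (beyond the scatter)). No measured evidence bears on this result.

Open is whether the methyl ester itself matters, since the free carboxylic acid or a primary amide at that end is not among the compounds shown. Also open, as far as these compounds go, is whether a shorter acetyl group on the amine nitrogen would hold the number.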